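A Methyl Next to the Ring Nitrogen of Compound 3

A few compounds are considered here, and "the series" means these few. Any claim that something is new, unique, unknown or untested is made for them only; others in the source may bear on it.

Compound 1, `Cc1c(C#Cc2ccc(CCC(=O)O)cc2)ccnc1Cl`, gives 135 nM in an in vitro functional assay on 1321-N1 cells for agonist activity at Free fatty acid receptor 1 (Homo sapiens), read by fluorescence, spectrophotometry and calcium flux; on this read-out higher numbers stand for an effect only at larger amounts of compound and lower numbers for an effect already at smaller amounts.
Compound 2, `O=C(O)CCc1ccc(C#Cc2ccnc(Cl)c2)cc1`, gives 295 nM in this assay.
Compound 3, `O=C(O)CCc1ccc(C#Cc2ccncc2)cc1`, gives 4070 nM in this assay.

Compound 4, `Cc1cc(C#Cc2ccc(CCC(=O)O)cc2)ccn1`, has not yet been measured in this assay. Its core and that of compound 2 differ by hydrogen in place of chloro on an aromatic carbon, a change that produced a 14-fold higher number from compound 2 to compound 3 (1.14 log units; beyond the scatter). The change from compound 3 to compound 4 is methyl in place of hydrogen on an aromatic carbon. The same kind of change, (methyl in place of hydrogen on an aromatic carbon), was made from compound 2 to compound 1 and gave a 2.2-fold lower number from compound 2 to compound 1 (0.34 log units; beyond the scatter); there the methyl sat ortho to a chloro group, ortho to a large group and two atoms from the ring nitrogen, whereas in compound 4 it sits next to the ring nitrogen and meta to a large group, so the surroundings are not the same. From compound 3 to compound 4 a step of a 3.1-fold lower number from compound 3 to compound 4 (0.50 log units; beyond the scatter) is expected in this assay, a little larger than the earlier one, because compound 3 at 4070 nM leaves more room for improvement. Compound 4 is therefore estimated at 1300 nM, with a likely range of 500 nM to 3500 nM.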

Compound 4, half-maximal effective concentration: 1120 nM
For compound 4 the middle estimate is 1.2-fold (0.06 log units) above the measured one; the range from low to high includes it.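

Methyl in place of hydrogen on an aromatic carbon gives a lower number on both cores in this assay, and the two steps do not differ beyond what repeated measurements would produce: the same change on two cores in this assay, a 2.2-fold lower number (0.34 log units; beyond the scatter) from compound 2 to compound 1 and a 3.6-fold lower number (0.56 log units; beyond the scatter) from compound 3 to compound 4, 1.7-fold (0.22 log units) apart, within the scatter of two such steps. In the new pair the methyl sits next to the ring nitrogen and the change gives a 3.6-fold lower number from compound 3 to compound 4 (0.56 log units; beyond the scatter), so across these two pairs the change carries over even though its surroundings are not the same. Two pairs make no rule for the series, however, and they cannot separate the effect of the core from that of the methyl's place, while the exchange of chloro for methyl gives a 3.8-fold higher number from compound 2 to compound 4 (0.58 log units; beyond the scatter), so on this evidence methyl does not match chloro on this core.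

From the compounds shown here alone, it remains open whether ethyl or methoxy in place of this methyl would move the number in the same direction. Going by these compounds, it is also open whether the step would hold on a core in which a tetrazole replaces the carboxylic acid.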